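Urea inhibitors: a hydroxymethyl group replaces fluorine

A few compounds are considered here, and "the series" means these few. Any claim that something is new, unique, unknown or untested is made for them only; others in the source may bear on it.

Measured so far:
compound 1 `CC(C)c1ccc(C2(CNC(=O)Nc3c(C(C)C)cccc3C(C)C)CCCC2)cc1` gives 48 nM
compound 2 `CC(C)c1cccc(C(C)C)c1NC(=O)NCC1(c2ccc(F)cc2)CCCC1` gives 23 nM
compound 3 `CC(C)c1cccc(C(C)C)c1NC(=O)NCC1(c2cccc(C(=O)O)c2)CCCC1` gives 620 nM

Of the compounds shown here, three sharing one core have been tested in an assay on microsomes for inhibition of acyl-CoA:cholesterol acyltransferase (Oryctolagus cuniculus); on this read-out lower numbers stand for stronger inhibition and higher numbers for weaker inhibition. Compound 2 gives the lowest number of the three: compound 1 lies a 2.1-fold lower number from compound 1 to compound 2 (0.32 log units; beyond the scatter) away from it, and compound 3 is far behind, at a 27-fold higher number from compound 2 to compound 3 (1.43 log units; beyond the scatter). Compound 3 also stands well apart from compound 1, as a 13-fold higher number from compound 1 to compound 3 (1.11 log units; beyond the scatter) shows.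

The next compound, compound 4 `CC(C)c1cccc(C(C)C)c1NC(=O)NCC1(c2ccc(CO)cc2)CCCC1`, differs from compound 2 at one point: hydroxymethyl in place of fluoro on an aromatic carbon.

For the measured compounds named here, two measured steps bear on this change. The step from compound 1 to compound 2 shows that swapping fluoro for another small substituent moved the number only modestly. The step from compound 2 to compound 3, where the phenyl ring gained a carboxylic acid, was large and unfavourable. Hydroxymethyl brings a hydrogen-bond donor and acceptor, as the carboxylic acid of compound 3 does, but no charge, so a loss is expected, smaller than that seen for compound 3. For compound 4 the expected step is a 4.8-fold higher number from compound 2 to compound 4 (0.68 log units; beyond the scatter), upward in this assay, beyond the scatter. Compound 4 is therefore estimated at 110 nM, in the range 35 nM to 350 nM.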

Compound 4, half-maximal inhibitory concentration: 26 nM
For compound 4 the middle estimate is 4.2-fold (0.63 log units) above the measured one, outside the stated range (below it).
By their numbers in this assay, from the lowest: compounds 2, 4 and 1 (each within the scatter of the next, the first and the last beyond it); then compound 3.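

In this assay, hydroxymethyl in place of fluoro gives a 1.1-fold higher number from compound 2 to compound 4 (0.05 log units; within the scatter), so at this position on the aromatic ring a group with a hydrogen-bond donor and acceptor fits as well as fluoro, which has neither. Hydroxymethyl in place of isopropyl reads the same way, with a 1.8-fold lower number from compound 1 to compound 4 (0.27 log units; within the scatter), so the two-heavy-atom hydroxymethyl cannot be told apart from either of these neighbouring groups in this assay. Against the carboxylic acid, the picture is very different, at a 24-fold lower number from compound 3 to compound 4 (1.38 log units; beyond the scatter), which shows that a hydrogen-bond donor and acceptor on this ring do not by themselves bring the loss seen for compound 3, although this step changes both the group and its place on the ring. Nothing measured here explains why the number stays level at this position.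

Still open, as far as these compounds go, is whether a carboxylic acid at the place para to a large group would cost as much as it does in the 3-carboxyphenyl ring, which would separate the effect of the group from that of its place. From the compounds shown here alone, it is equally open whether an amine or a longer chain ending in hydroxyl would fit here as well as hydroxymethyl does.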